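A methyl added to a compound at the limit

The compounds below may be only part of what the source reports. "The series", "measured", "known", "first", "only" and "open" are said of these compounds alone.

In an ADME assay on MT4 cells (Homo sapiens) for cytotoxicity, read by MTT assay, with a stated time of 4 days (on this read-out higher numbers stand for lower toxicity in this test and lower numbers for higher toxicity in this test), compound 1 `O=c1cc(Cc2c(F)cccc2F)nc(N2CCCC2)[nH]1` gives > 86000 nM as a limit and not a number. Compound 2 `O=c1cc(Cc2c(F)cccc2N2CCCC2)nc(N2CCCC2)[nH]1` gives > 73000 nM as a limit too, so it stands without a number of its own. Within the data shown here, the one measured step (a step that the two limits leave unreadable from compound 1 to compound 2) puts pyrrolidin-1-yl in place of fluoro on an aromatic carbon, and it offers no size to carry forward.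

Compound 4 `Cc1c(Cc2c(F)cccc2N2CCCC2)nc(N2CCCC2)[nH]c1=O` differs from compound 2 by a single change (methyl in place of hydrogen on an aromatic carbon) in which methyl replaces hydrogen on an aromatic carbon of the six-membered aromatic ring with 2 nitrogen. Compound 3 `Cc1c(Cc2c(F)cccc2F)nc(N(C)C(C)C)[nH]c1=O` also carries methyl on an aromatic carbon of the shared core and gives 79000 nM as a true number, so no step beyond the scatter is expected in this assay and no direction is favoured. The estimated step (a step that the limit leaves unreadable from compound 2 to compound 4) is expected to stay small. For compound 4 the estimate is 75000 nM with an expected range of 35000 nM to 150000 nM and a limit may well be expected again.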

Compound 4, half-maximal cytotoxic concentration: > 70000 nM
Compound 4 ended at the assay's limit; the forecaster's own chance of this, stated with the estimate: 60%; the middle value is on the limit's open side.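

In this assay compound 4 gives > 70000 nM, a limit and not a number. Compound 2 also stands at a limit, and no step can be read between compound 2 and compound 4. The compounds shown leave open whether methyl in place of hydrogen changes this read-out at all.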